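The compounds below may be only part of what the source reports. "The series", "measured", "known", "first", "only" and "open" are said of these compounds alone.

Three compounds have been measured in a functional assay on HEK293 cells (Homo sapiens) for inhibition; a higher number here means a weaker inhibitor, a lower number a stronger inhibitor:

compound 1, `CCCCCCCCCCS(=O)(=O)NCCCN(CCCNCCCCNCCCN)CCCNS(=O)(=O)CCCCCCCCCC`, gives 5170 nM;
compound 2, `CCCCCCCCCCCCCCCCS(=O)(=O)NCCCN(CCCNCCCCNCCCN)CCCNS(=O)(=O)CCCCCCCCCCCCCCCC`, gives 4850 nM;
compound 3, `CCCCCCCCCCS(=O)(=O)NCCCN(CCCNCCCNCCCCNCCCN)CCCNS(=O)(=O)CCCCCCCCCC`, gives 2200 nM.

A fourth compound, compound 4, `CCCCCCCCCCCCCCCCS(=O)(=O)NCCCN(CCCNCCCNCCCCNCCCN)CCCNS(=O)(=O)CCCCCCCCCCCCCCCC`, has not yet been measured in this assay.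

All four share the same pattern: a branched chain of amines capped at two ends by sulfonamides carrying long saturated chains. Compound 1 and compound 2 differ in the length of those chains, but the difference between the two cores is not broken down here. In this assay their two values lie within the usual scatter of each other, so nothing can be said about which of the two is the stronger inhibitor.

Compound 3 is made from compound 1 by one change: (4-((3-aminopropyl)amino)butyl)amino in place of ((3-aminopropyl)amino)methyl on a saturated chain carbon, three bonds along the chain from an amine nitrogen. This change produced a 2.4-fold lower number from compound 1 to compound 3 (0.37 log units; beyond the scatter).

Compound 4 is made from compound 2 by the same change, at the same place: (4-((3-aminopropyl)amino)butyl)amino in place of ((3-aminopropyl)amino)methyl on a saturated chain carbon, three bonds along the chain from an amine nitrogen. Nothing in the data suggests that the longer sulfonamide chains of compound 2 should alter how this change plays out, so the step is expected to be of about the same size as the one already seen. The step from compound 2 to compound 4 in this assay is therefore expected to be a 2.3-fold lower number from compound 2 to compound 4 (0.36 log units; beyond the scatter). On that basis compound 4 is estimated to give 2100 nM in this assay, most likely between 1000 nM and 4500 nM.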

Compound 4, half-maximal inhibitory concentration: 2680 nM
Beside the measured number, compound 4's estimate is 1.3-fold (0.11 log units) below it; the measured number falls inside the stated range.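

In this assay the new step is a 1.8-fold lower number from compound 2 to compound 4 (0.26 log units; within the scatter) and so, taken alone, cannot be told apart from the differences seen between repeated measurements. Set beside the earlier step, it gives no sign that the change behaves differently on the two cores: the same change on two cores in this assay, a 2.4-fold lower number (0.37 log units; beyond the scatter) from compound 1 to compound 3 and a 1.8-fold lower number (0.26 log units; within the scatter) from compound 2 to compound 4, 1.3-fold (0.11 log units) apart, within the scatter of two such steps. This shows that the result on the core of compound 1 and the result on the core of compound 2 are compatible, and that the longer sulfonamide chains do not visibly alter what the change does, but it does not show a real gain on the core of compound 2, and two cores are too few to make a rule for the series.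

The compounds shown leave open whether the same agreement would hold with sulfonamide chains of other lengths, such as a dodecyl chain, or with an amide in place of the sulfonamide. They also leave open what happens when the amine arm is extended further, or when its end amine is replaced by an acetamide or a carboxylic acid.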